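This account rests on a few compounds, and the source may have more. Where it says the series, first, only, none or still open, it means among the compounds named here.

Working notes on the series. In an ADME assay (liver) for metabolic stability, with Liver microsome (Homo sapiens) as the target, using microsomes and NADPH, with a stated time of 30 min, tested at 1 uM (on this read-out lower numbers stand for slow clearance and higher numbers for fast clearance), compound 1 (`Cc1csc(-c2cc(C(O)(C(F)(F)F)C(F)(F)F)cnc2N2CCN(S(=O)(=O)c3ccc(N)nc3)CC2)c1`) gives 29 mL.min-1.g-1 and compound 2 (`Nc1ccc(S(=O)(=O)N2CCN(c3ncc(C(O)(C(F)(F)F)C(F)(F)F)cc3-c3ccccc3O)CC2)cn1`) gives 22 mL.min-1.g-1 while compound 3 (`NC(=O)c1cccc(-c2cc(C(O)(C(F)(F)F)C(F)(F)F)cnc2N2CCN(S(=O)(=O)c3ccc(N)nc3)CC2)c1`) gives 17 mL.min-1.g-1 on the same shared core. Compound 3 stands within the scatter of both others, with a 1.7-fold lower number from compound 1 to compound 3 (0.23 log units; within the scatter) and a 1.3-fold lower number from compound 2 to compound 3 (0.11 log units; within the scatter) as the steps that reach it, and the remaining step (a 1.3-fold lower number from compound 1 to compound 2 (0.12 log units; within the scatter)) also stays inside the scatter. Compound 4 (`COc1cncc(-c2cc(C(O)(C(F)(F)F)C(F)(F)F)cnc2N2CCN(S(=O)(=O)c3ccc(N)nc3)CC2)c1`) has 5-methoxypyridin-3-yl in place of 3-carbamoylphenyl on an aromatic carbon. Among the measured compounds shown here, no measured step covers this exact exchange, but all three measured steps change the group at this same place. Even the widest of them (a 1.7-fold lower number from compound 1 to compound 3 (0.23 log units; within the scatter)) stays within the scatter, so no step beyond the scatter is expected in this assay here. The estimated step is small (a 1.3-fold higher number from compound 3 to compound 4 (0.11 log units; within the scatter)) and lies within the scatter. The estimated value for compound 4 is 22 mL.min-1.g-1 and the expected range runs from 12 mL.min-1.g-1 to 38 mL.min-1.g-1 in this read-out.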

Compound 4, intrinsic clearance in microsomes: 44 mL.min-1.g-1
Estimate against measurement, compound 4: 2.0-fold (0.30 log units) below; measured number above the stated range.
By their numbers in this assay, from the lowest: compounds 3, 2, 1 and 4 (each within the scatter of the next, the first and the last beyond it).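

In this assay, this position, ortho to a large group, now gives its first step beyond the scatter, though a modest one (a 2.6-fold higher number from compound 3 to compound 4 (0.41 log units; beyond the scatter)), with 5-methoxypyridin-3-yl in place of 3-carbamoylphenyl. The same entering group stays within the scatter against the other two groups (a 2.0-fold higher number from compound 2 to compound 4 (0.30 log units; within the scatter); a 1.5-fold higher number from compound 1 to compound 4 (0.18 log units; within the scatter)), so the exchange separates only the two ends of the series, and the middle of the set remains unresolved. Nothing measured here speaks to the origin of this step.

The exchange replaces the ring and its substituent together, and the compounds shown do not separate the two; a 3-methoxyphenyl group at this place would do so. Where an aminomethyl group or a carboxylic acid at this place would fall also remains open.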